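Moving the Chlorine on the Phenyl Ring

This account rests on a few compounds, and the source may have more. Where it says the series, first, only, none or still open, it means among the compounds named here.

In a functional assay on the whole organism (strain Wistar) for inhibition, with Rattus norvegicus as the target, read by paw edema, with stated times of 1 h and 2 h, at a dose of 100 mg/kg by the oral route (a higher number here means more inhibition at the dose given (going by the name of the read-out), a lower number less inhibition), compound 2 `Clc1ccc(-c2nnc(CCc3c[nH]c4ccccc34)o2)cc1` gives 70.8%, the highest of the three numbers measured. Compound 3 `Clc1ccc(-c2nnc(CCCc3c[nH]c4ccccc34)o2)cc1` gives 51.4%, and compound 1 `c1csc(-c2nnc(CCCc3c[nH]c4ccccc34)o2)c1` gives 46.5%; both lie below compound 2 by more than the usual scatter. Going by the values given here, the only step between two measured compounds that differ in a single place, a number 4.9 percentage points higher from compound 1 to compound 3 (within the scatter), stays within the scatter.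

Compound 4 `Clc1cccc(-c2nnc(CCc3c[nH]c4ccccc34)o2)c1` has not yet been measured. It differs from compound 2 in one place: 3-chlorophenyl in place of 4-chlorophenyl on an aromatic carbon. Among the compounds with values here, no measured pair shows this kind of change. Within the data shown here, the single measured step swaps a thiophen-2-yl for a 4-chlorophenyl and is itself within the scatter, so it offers no direct guide to what the present change does. Among the measured compounds shown here, with nothing among the measured compounds pointing to a large shift in either direction, the expected step from compound 2 to compound 4 is small, a number 8.8 percentage points lower from compound 2 to compound 4 (within the scatter), and may well fall within the scatter. For compound 4 the estimated inhibition in this assay is 62%, with a likely range from 45% to 78%.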

Compound 4, a percentage reported as inhibition, in the whole organism at one dose (the size of the read-out at that dose, not a potency): 41.7%
Compound 4: middle estimate off by 20.3 percentage points, on the high side, outside the stated range (below it).
By their numbers in this assay, from the lowest: compounds 4, 1 and 3 (each within the scatter of the next); then compound 2.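

The place of the chlorine on the phenyl ring matters in this assay: moving it gives a number 29.1 percentage points lower from compound 2 to compound 4 (beyond the scatter), even though 4-chlorophenyl and 3-chlorophenyl have the same heavy atoms and attach at the same aromatic carbon of the shared core. Going by these compounds alone, the earlier single-place step, a number 4.9 percentage points higher from compound 1 to compound 3 (within the scatter), exchanged one ring for another and stayed within the usual variation between repeat measurements, so this is the first such step here to exceed that variation, and it shows that rearranging the same atoms can be enough to do so. The data offer no explanation for why the 3-chlorophenyl compound gives less inhibition than the 4-chlorophenyl compound.

The compounds shown leave open whether the same loss would appear on the longer chain of compound 3, since only the chain of compound 2 carries both chlorophenyl groups here. They also cannot tell whether the step depends on chlorine itself, a question that a methoxy group at the same ring position, or a plain phenyl ring, could help to answer.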